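Methyl for Methoxy on the Urea Aryl Ring

The compounds below may be only part of what the source reports. "The series", "measured", "known", "first", "only" and "open" are said of these compounds alone.

Of the compounds shown here, two built on one shared core have been measured in a functional assay on HepG2 cells (Homo sapiens) for antiproliferative activity, read by MTT assay, with a stated time of 48 h; a lower number here means a stronger inhibitor, a higher number a weaker inhibitor. Compound 1 `O=C(Nc1cccc(Cl)c1)Nc1nnc(Sc2ncnc3scc(-c4ccncc4)c23)s1` gives 22900 nM. Compound 2 `COc1ccc(NC(=O)Nc2nnc(Sc3ncnc4scc(-c5ccncc5)c34)s2)cc1` gives 14600 nM. Within the data shown here, the only step measured so far, a 1.6-fold lower number from compound 1 to compound 2 (0.20 log units; within the scatter), exchanged one substituted aryl ring for another on the urea nitrogen and barely moved the number, so compound 2 and compound 1 cannot be separated on these data.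

Compound 3 `Cc1ccc(NC(=O)Nc2nnc(Sc3ncnc4scc(-c5ccncc5)c34)s2)cc1` differs from compound 2 by methyl in place of methoxy on an aromatic carbon, a smaller change than the one already measured. Among the measured compounds shown here, the one step that bears on such an exchange on this ring is a 1.6-fold lower number from compound 1 to compound 2 (0.20 log units; within the scatter), and it stayed within the scatter, so with a single example nothing points to a large move in either direction. The step expected here is a 1.0-fold higher number from compound 2 to compound 3 (0.01 log units; within the scatter). Compound 3 is therefore estimated at 15000 nM, with a likely range from 7000 nM to 32000 nM.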

Compound 3, half-maximal inhibitory concentration: 52000 nM
Compound 3: middle estimate off by 3.5-fold (0.54 log units), on the low side, outside the stated range (above it).
By their numbers in this assay, from the lowest: compounds 2 and 1 (each within the scatter of the next); then compound 3.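

Methyl in place of methoxy on this aromatic carbon, para to a large group, gives a 3.6-fold higher number from compound 2 to compound 3 (0.55 log units; beyond the scatter) and, unlike the step between the two earlier compounds, stands beyond the scatter, so this ring's substituent can shift the number. The 4-methylphenyl compound also differs from the 3-chlorophenyl compound, with a 2.3-fold higher number from compound 1 to compound 3 (0.36 log units; beyond the scatter) as a second modest step, which leaves compound 3 the weakest of the three. No measurement shown here explains the loss of activity.

As far as these compounds go, whether the oxygen of the methoxy group matters, or something else about the exchange, remains open. A hydroxyl, an ethoxy or a dimethylamino group on the same aromatic carbon, or an unsubstituted phenyl ring, would help show how far this trend extends.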